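The source may report more compounds than this note shows. Statements on the series, on what has been measured and on what is new or still open speak of the compounds shown alone.

Measured compounds in the series: compound 1 `Cn1nnnc1SCC(=O)N/N=C/c1ccc(Br)cc1` with 10000000 nM and compound 2 `Cn1nnnc1SCC(=O)N/N=C/c1ccc(O)cc1` with 632000 nM.

Both numbers come from an ADME assay on NIH3T3 cells (Mus musculus) for cytotoxicity, read by XTT assay, with a stated time of 24 h; on this read-out lower numbers stand for stronger inhibition and higher numbers for weaker inhibition. Within the two values shown, compound 1 stands at the higher one; the only neighbour, compound 2, lies at a 16-fold lower number from compound 1 to compound 2 (1.20 log units; beyond the scatter), a step that exceeds the usual scatter.

The step under consideration leads from compound 1 to compound 3 `COc1ccc(/C=N/NC(=O)CSc2nnnn2C)cc1`: methoxy in place of bromo on an aromatic carbon. Among the compounds with values here, the one measured step that bears on it is the exchange of bromo for hydroxy at the same place, a 16-fold lower number from compound 1 to compound 2 (1.20 log units; beyond the scatter). Methoxy shares the oxygen of hydroxy but carries no hydrogen-bond donor, so the step is expected to go in the same direction, toward a lower number, but probably not as far.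

Estimated for compound 3 in this assay: 2000000 nM (range 400000 nM to 10000000 nM), meaning an expected step of a 5.0-fold lower number from compound 1 to compound 3 (0.70 log units; beyond the scatter).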

Compound 3, half-maximal inhibitory concentration: > 10000000 nM
Compound 3: no number, only a limit; the forecaster's own chance of this, stated with the estimate: 30%; middle value at least 5.0-fold (0.69 log units) away from the limit.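

In this assay the two oxygen-linked groups at this aromatic carbon do not behave alike: methyl in place of hydrogen on the oxygen gives an at least 15-fold higher number from compound 2 to compound 3 (1.19 log units; beyond the scatter) and the lower number seen with hydroxy does not extend to methoxy. Among these compounds, an oxygen on this carbon is therefore not enough for a lower number; only the free hydroxy of compound 2 shows one. Compound 3 gives a limit rather than a number: the limit of > 10000000 nM in this assay, at which 1 of the 3 values shown sits. Methoxy in place of bromo gives a number no lower from compound 1 to compound 3 (the limit leaves the size open).

Going by these compounds, it remains open how far compound 3 lies from compound 1. On these data alone, it is also open whether an amine or a carboxylic acid on the same aromatic carbon would give a lower number like hydroxy, or stay at the limit like methoxy.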